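A few compounds are considered here, and "the series" means these few. Any claim that something is new, unique, unknown or untested is made for them only; others in the source may bear on it.

Of the compounds shown here, three have been measured in an assay on HEK293 cells for positive allosteric modulation of metabotropic glutamate receptor 2 (Rattus norvegicus), read by thallium flux, with a stated time of 2.5 min; a lower number here means that less compound is needed, a higher number that more compound is needed for the effect. Compound 1 `Cc1c(OCCCCOc2ccc(C(=O)O)cc2)ccc(C(=O)CC2CCCC2)c1O` gives 824 nM, compound 2 `Cc1ccc(C(=O)O)cc1OCCCCOc1ccc(C(=O)CC2CCCC2)c(O)c1C` gives 1290 nM, and compound 3 `Cc1cc(C(=O)O)ccc1OCCCCOc1ccc(C(=O)C(C)C)c(O)c1C` gives 234 nM, the lowest number of the three. Among the measured compounds shown here, the only single-point step so far, a 1.6-fold higher number from compound 1 to compound 2 (0.19 log units; within the scatter), concerns the aryl group on the ether oxygen and not the ketone side chain. Compound 4 `Cc1cc(C(=O)O)ccc1OCCCCOc1ccc(C(=O)CC2CCCC2)c(O)c1C` differs from compound 3 by cyclopentylmethyl in place of isopropyl on a carbonyl carbon. For the measured compounds named here, no measured step isolates that change; compounds 1 and 2, which carry the same cyclopentylmethyl ketone but a different aryl group, both show higher numbers than compound 3. On that basis compound 4 is expected to show a modestly higher number, an estimated step of a 2.6-fold higher number from compound 3 to compound 4 (0.41 log units; beyond the scatter). Compound 4 is estimated at 600 nM, with a range of 200 nM to 1800 nM.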

Compound 4, half-maximal effective concentration: 608 nM
Compound 4: the middle estimate sits 1.0-fold (0.01 log units) below what was measured, within the range that was stated.
By their numbers in this assay, from the lowest: compound 3; then compounds 4, 1 and 2 (each within the scatter of the next, the first and the last beyond it).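

In this assay the ketone side chain now has a single-point step of its own: a 2.6-fold higher number from compound 3 to compound 4 (0.41 log units; beyond the scatter) comes with cyclopentylmethyl in place of isopropyl on a carbonyl carbon. With cyclopentylmethyl held, a 2.1-fold lower number from compound 2 to compound 4 (0.33 log units; beyond the scatter) shows that the place of the carboxy group on the methylphenyl ring also counts, while a 1.4-fold lower number from compound 1 to compound 4 (0.13 log units; within the scatter) comes with methyl in place of hydrogen on an aromatic carbon. Nothing measured here offers a reason for these steps.

The compounds shown leave open how a tetrazole in place of the carboxylic acid, or a cyclohexylmethyl group on the carbonyl carbon, would read in this assay on this core.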